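The source may report more compounds than this note shows. Statements on the series, on what has been measured and on what is new or still open speak of the compounds shown alone.

Compound 2, `CCCc1nnsc1CO/N=C/c1c(C)nn(C)c1Oc1ccc(Cl)cc1`, in this assay: > 50000 nM.
Compound 1, `Cc1nnsc1CO/N=C/c1c(C)nn(C)c1Oc1ccc(C(C)(C)C)cc1`, in this assay: > 50000 nM.

Of the compounds shown here, two have so far been measured in a functional assay on PANC-1 cells (Homo sapiens) for inhibition, read by MTT assay, with a stated time of 48 h; on this read-out lower numbers stand for stronger inhibition and higher numbers for weaker inhibition. For compound 2 the reported value is a limit of the assay, > 50000 nM, and not a number. For compound 1 the reported value is likewise a limit, > 50000 nM. Both values therefore sit at the limit of > 50000 nM in this assay, at which 2 of the 2 values shown sit, so compound 2 stands together with the other measured compound at that limit, and nothing separates the two within the numbers shown.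

Compound 3, `CCCc1nnsc1CO/N=C/c1c(C)nn(C)c1Cl`, has not yet been measured. It differs from compound 2 by chloro in place of 4-chlorophenoxy on an aromatic carbon. For the measured compounds named here, no step between measured compounds is available to lean on, and the only footing is the limit at which compound 2 sits.

Compound 3 is therefore expected to give roughly 70000 nM, with a range from 20000 nM to 250000 nM, and most probably the assay will again report only a limit. The estimate thus means an expected step that the limit leaves unreadable from compound 2 to compound 3, which is none beyond the scatter.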

Compound 3, half-maximal inhibitory concentration: > 50000 nM
Compound 3 gave a limit, no number (the forecaster's own chance of this, stated with the estimate: 80%); the middle value lies beyond the limit too.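

In this assay compound 3 gives > 50000 nM, which is a limit and not a number. Compound 2 also stands at a limit, so no step can be read between compound 2 and compound 3. All the values shown sit together: the limit of > 50000 nM in this assay, at which 3 of the 3 values shown sit. The compounds shown leave open how strongly any of them inhibits, and whether exchanging 4-chlorophenoxy for chloro changes this at all.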